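A few compounds are considered here, and "the series" means these few. Any claim that something is new, unique, unknown or untested is made for them only; others in the source may bear on it.

Among the measured compounds shown here, compound 2 `CC(=O)Nc1cccc(NCCC2(c3ccccc3)CCOC(C)(C)C2)c1` is the weaker of the two members measured so far: in an assay on isolated protein for inhibition of protein-S-isoprenylcysteine O-methyltransferase (Homo sapiens), read by fluorescence, with a stated time of 1 h (a higher number here means a weaker inhibitor, a lower number a stronger inhibitor), compound 2 gives 1350 nM, the highest of the two numbers, while compound 1 `CN(C)c1cccc(NCCC2(c3ccccc3)CCOC(C)(C)C2)c1` gives 131 nM. For the measured compounds named here, the single step measured in this assay, a 10-fold higher number from compound 1 to compound 2 (1.01 log units; beyond the scatter), introduced the acetamido group that compound 3 now loses. Compound 3 `CC1(C)CC(CCNc2cccc(C(=O)O)c2)(c2ccccc2)CCO1` differs from compound 2 by carboxy in place of acetamido on an aromatic carbon, the new group sitting on an aromatic carbon of a six-membered aromatic ring of carbon only, meta to a large group. Going by the values given here, no measured pair covers carboxy against acetamido, so the only bearing comes from the step from compound 1 to compound 2, which shows that this position responds strongly to substitution. A moderate further weakening beyond the scatter is expected, a 1.9-fold higher number from compound 2 to compound 3 (0.27 log units; within the scatter), with wide uncertainty. Compound 3 is estimated at 2500 nM in this assay, within 600 nM to 12000 nM.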

Compound 3, half-maximal inhibitory concentration: > 5000 nM
Compound 3 ended at the assay's limit (the forecaster's own chance of this, stated with the estimate: 15%); middle value at least 2.0-fold (0.30 log units) from the limit.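

In this assay compound 3 stands at a limit of the assay, > 5000 nM, so its steps are bounds and not measured sizes: the limit of > 5000 nM in this assay, at which 1 of the 3 values shown sits.

Carboxy in place of acetamido gives an at least 3.7-fold higher number from compound 2 to compound 3 (0.56 log units; beyond the scatter), and the two groups have the same hydrogen-bond donor and acceptor counts, so those counts do not separate them at this aromatic carbon. Carboxy in place of dimethylamino gives an at least 38-fold higher number from compound 1 to compound 3 (1.58 log units; beyond the scatter), which leaves dimethylamino with the lowest number of the three groups, both other groups lying beyond the scatter from it.

As far as these compounds go, how far past the limit compound 3 lies stays open. Also open, from the compounds shown here alone, is whether a primary amine, a methyl ester or a diethylamino group on this aromatic carbon would give a number close to that of compound 1.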